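The compounds below may be only part of what the source reports. "The series", "measured", "known", "first", "only" and "open" are said of these compounds alone.

Among the measured compounds shown here, in an assay for binding affinity to 17-beta-hydroxysteroid dehydrogenase type 2 (Homo sapiens), with a stated time of 20 min, tested at 1 uM (a lower number here means less inhibition, a higher number more inhibition at the concentration tested (going by the name of the read-out)), three compounds have numbers so far. For the measured compounds named here, compound 1 `Oc1ccc2cc(-c3ccccc3O)ccc2c1` gives only a limit of this assay, < 10%, the single value sitting at that floor (the limit of < 10% in this assay, at which 1 of the 3 values shown sits). Compound 2 `Oc1cccc(-c2ccc3ccccc3c2)c1` gives 12% in this assay. Compound 3 `OCc1ccc(-c2ccc3c(O)cccc3c2)cc1` gives 31%, the highest of the two numbers shown, with compound 2 the nearest and lower by a margin beyond the scatter. Compound 4 `CC(=O)c1ccc(-c2ccc3c(O)cccc3c2)cc1` is not yet measured; it differs from compound 3 by acetyl in place of hydroxymethyl on an aromatic carbon. Going by the values given here, no measured pair shows this change, so its size is uncertain. The step is expected to be a number 6 percentage points lower from compound 3 to compound 4 (within the scatter), a slight fall within the scatter. Compound 4 is expected to give 25%, somewhere between 5% and 50%.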

Compound 4, a percentage reported as inhibition, at one concentration (the size of the read-out at that concentration, not a potency): < 10%
Compound 4 ended at the assay's limit (the forecaster's own chance of this, stated with the estimate: 30%); middle value at least 15 percentage points away from the limit.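

In this assay, acetyl in place of hydroxymethyl on an aromatic carbon, para to a large group, gives a number at least 21 percentage points lower from compound 3 to compound 4 (beyond the scatter). Among the compounds shown here, this is the first comparison of compounds differing in one place, and it shows that the group at this position matters for the read-out. Compound 4 gives < 10%, which is a limit of the assay: the limit of < 10% in this assay, at which 2 of the 4 values shown sit.

As far as these compounds go, whether an amine, a carboxylic acid or a longer chain at this position would keep the number remains open. So does whether the fall follows the hydrogen-bond donor that leaves with hydroxymethyl or the carbon that enters with acetyl.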